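Threonine-type side chain on a glycine benzyl ester

The source may hold more compounds than are shown below. What is called first, only, known or untested is meant among the compounds shown, and "the series" means these compounds.

Compound 1, `O=C(CN(c1nc(Cl)nc2[nH]cnc12)C1CC1)NCC(=O)OCc1ccccc1`, gives 27.2% in a functional assay on the whole organism (Tail, strain ICR) with Mus musculus as the target, in the tail flick test, with a stated time of 90 min, at a dose of 25 umol/kg by the oral route; on this read-out lower numbers stand for a weaker effect and higher numbers for a stronger effect at the one dose given.
Compound 2, `CSCC[C@H](NC(=O)CN(c1ncnc2c1ncn2C1CCCCO1)C1CC1)C(=O)OCc1ccccc1`, gives 42.7% in this assay.
Compound 3, `CSCC[C@H](NC(=O)CN(c1nc(Cl)nc2[nH]cnc12)C1CC1)C(=O)O`, gives 14% in this assay.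

Among these three numbers compound 1 stands second highest: compound 3 lies lower by more than the scatter, and compound 2 lies higher by more than the scatter. Among the measured compounds shown here, no two measured compounds differ in just one place, so no single change has yet been followed.

Compound 4, `C[C@@H](O)[C@H](NC(=O)CN(c1nc(Cl)nc2[nH]cnc12)C1CC1)C(=O)OCc1ccccc1`, differs from compound 1 by 1-hydroxyethyl in place of hydrogen on a saturated chain carbon bound to an amide-type nitrogen and a carbonyl carbon. Compound 2 also carries a side chain on that carbon and gives 42.7%, but its core is another one, so it offers only a loose hint.

The step from compound 1 to compound 4 is expected to be small and upward, a number 5.8 percentage points higher from compound 1 to compound 4 (within the scatter), within the scatter. Compound 4 is expected to give about 33%, between 15% and 50%.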

Compound 4, a percentage reported as activity, at one dose (the size of the read-out at that dose, not a potency): 29.9%
Estimate against measurement, compound 4: 3.1 percentage points above; low and high end bracket the measured number.
By their numbers in this assay, from the lowest: compound 3; then compounds 1 and 4 (each within the scatter of the next); then compound 2.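

In this assay, among the compounds shown here, the first single change that can be followed, 1-hydroxyethyl in place of hydrogen on a saturated chain carbon bound to an amide-type nitrogen and a carbonyl carbon, gives a number 2.7 percentage points higher from compound 1 to compound 4 (within the scatter) on the shared core. This position therefore carries that side chain with no difference that can be told from the scatter. No measurement here explains this outcome.

Still open, on these data alone, is whether a 4-aminobutyl chain or a benzyl group on this carbon would move the number beyond the scatter.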